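Trimming the chalcone arm: expected tolerability of compound 4

A few compounds are considered here, and "the series" means these few. Any claim that something is new, unique, unknown or untested is made for them only; others in the source may bear on it.

Measured compounds:
Compound 1 `O=C(COc1ccccc1C(=O)/C=C/c1ccc(Cl)cc1)NCCNc1ccnc2cc(Cl)ccc12` gives 4980 nM.
Compound 2 `COc1ccc(/C=C/C(=O)c2ccccc2OCC(=O)NCCNc2ccnc3cc(Cl)ccc23)cc1` gives 25000 nM.
Compound 3 `O=C(/C=C/c1ccco1)NCCNc1ccnc2cc(Cl)ccc12` gives 629000 nM.

These numbers come from an ADME assay on Vero cells (Chlorocebus sabaeus) for cytotoxicity, read by MTT assay, with a stated time of 72 h; a lower number here means that less compound is tolerated, a higher number that more compound is tolerated. Among the three, compound 2 holds the second highest number: its nearest neighbour is compound 1, and the only single-change step recorded, a 5.0-fold higher number from compound 1 to compound 2 (0.70 log units; beyond the scatter), separates the two. Compound 3, which carries a quite different side arm, sits far away at the top.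

Compound 4 `CC(=O)c1ccccc1OCC(=O)NCCNc1ccnc2cc(Cl)ccc12` differs from compound 2 by methyl in place of 2-(4-methoxyphenyl)ethenyl on a carbonyl carbon. Among the compounds with values here, no measured step covers exactly this change. The step from compound 1 to compound 2 swaps one substituent on the distant ring, not the whole arm, so it gives little guidance. The values of compound 2 and compound 3 show that a compound lacking the extended aryl arm is tolerated far better, though that pair differs in more than one place.

On that basis compound 4 is expected to be tolerated better than compound 2, the estimated step being a 4.0-fold higher number from compound 2 to compound 4 (0.60 log units; beyond the scatter). The estimate for compound 4 is 100000 nM, with a plausible range from 25000 nM to 400000 nM.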

Compound 4, half-maximal cytotoxic concentration: 106000 nM
Estimate against measurement, compound 4: 1.1-fold (0.03 log units) below, within the range that was stated.
By their numbers in this assay, from the lowest: compound 1; then compound 2; then compound 4; then compound 3.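

In this assay, within the data shown here, methyl in place of 2-(4-methoxyphenyl)ethenyl on the carbonyl carbon gives a 4.2-fold higher number from compound 2 to compound 4 (0.63 log units; beyond the scatter), the first reading of this arm as a single change rather than of a substituent at its far end. Methyl in place of 2-(4-chlorophenyl)ethenyl at the same place gives a 21-fold higher number from compound 1 to compound 4 (1.33 log units; beyond the scatter), so both extended arms go with a lower number in this assay than the small acetyl group does. Nothing available explains why removing either arm has this effect.

The compounds shown jump from the full arm straight to methyl, so they leave open whether the double bond, the aromatic ring or simply the size of the arm matters. A simple ethyl group, a longer saturated chain or an amine on that carbonyl carbon could land nearer compound 4 or nearer compound 2.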